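Trimming the Amidine Carbon Substituent in a Chloroquinoline Series

This account rests on a few compounds, and the source may have more. Where it says the series, first, only, none or still open, it means among the compounds named here.

Measured in an ADME assay (liver) for metabolic stability, with Liver microsome (Homo sapiens) as the target, read by LC-MS, using microsomes, tested at 1 uM; a higher number here means that the compound lasts longer, a lower number that the compound disappears faster:
- compound 1 `CCN(CC)CCCCN/C(=N\c1ccnc2cc(Cl)ccc12)C(C)C`: 0.917 h
- compound 2 `CCN(CC)CCN/C(=N\c1ccnc2cc(Cl)ccc12)C(C)C`: > 1 h
- compound 3 `CN(C)CCC/N=C(\c1ccccc1)N(CCCN(C)C)c1ccnc2cc(Cl)ccc12`: > 1 h

Compound 2 sits at a limit of this assay, > 1 h, so its half-life is known only as a bound and not as a number. Compound 3 likewise stops at a limit, > 1 h. Among the measured compounds shown here, compound 1 gives a real number, 0.917 h, and the one step between neighbours, an at least 1.0-fold higher number from compound 1 to compound 2 (0.03 log units; that floor lies within the scatter), is within the scatter; it concerns only the chain length and tells nothing about the part changed next. Notably (the limit of > 1 h in this assay, at which 2 of the 3 values shown sit).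

Compound 4 `CCN(CC)CCN/C(C)=N\c1ccnc2cc(Cl)ccc12` differs from compound 2 in one place: methyl in place of isopropyl on a carbon with a double bond to nitrogen. For the measured compounds named here, no measured step touches this carbon, so the expectation rests on compound 2 alone. The change is expected to move the half-life little, giving an estimated step of an at least 1.1-fold lower number from compound 2 to compound 4 (0.04 log units; that floor lies within the scatter), and compound 4 is estimated at 0.9 h, with a range from 0.4 h to 1.8 h, since compound 2 itself offers only > 1 h as a starting point.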

Compound 4, half-life: 0.433 h
Estimate against measurement, compound 4: 2.1-fold (0.32 log units) above; low and high end bracket the measured number.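

In this assay, the carbon with a double bond to nitrogen responds where the chain change did not: swapping isopropyl for methyl gives an at least 2.3-fold lower number from compound 2 to compound 4 (0.36 log units; beyond the scatter). The half-life therefore depends on which group sits on this carbon, and the smaller group here goes with the faster disappearance. The printed size is only a floor, and the real gap may be wider, because compound 2 carries a limit rather than a number: the limit of > 1 h in this assay, at which 2 of the 4 values shown sit.

The compounds shown leave open whether an ethyl or cyclopropyl group on this carbon would behave more like isopropyl or more like methyl. Going by these compounds, it also remains open whether the same swap would have a similar effect on the longer chain of compound 1.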